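This account rests on a few compounds, and the source may have more. Where it says the series, first, only, none or still open, it means among the compounds named here.

Measured compounds in a functional assay on SK-MEL-2 cells (Homo sapiens) for inhibition, read by sulforhodamine B assay, with a stated time of 48 h; on this read-out lower numbers stand for stronger inhibition of growth and higher numbers for weaker inhibition of growth:

compound 1 `Nc1cc(N)c2nc(-c3ccccc3)c(NCc3ccc(Cl)c(Cl)c3)nc2c1`: 4270 nM
compound 2 `COc1ccc(CNc2nc3cc(N)cc(N)c3nc2-c2ccccc2)cc1OC`: 30200 nM
compound 3 `Nc1cc(N)c2nc(-c3ccccc3)c(NCc3ccc(F)cc3)nc2c1`: < 100000 nM, a limit of the assay

Compound 3 thus stands only at a limit of this assay, with no number of its own. The step to compound 4 `Nc1cc(N)c2nc(-c3ccccc3)c(Sc3ccc(Cl)c(Cl)c3)nc2c1` is (3,4-dichlorophenyl)sulfanyl in place of (4-fluorobenzyl)amino on an aromatic carbon. Among the measured steps, a 7.1-fold higher number from compound 1 to compound 2 (0.85 log units; beyond the scatter) shows that the ring on the chain matters, while a step that the limit leaves unreadable from compound 1 to compound 3 and a step that the limit leaves unreadable from compound 2 to compound 3 cannot be sized, owing to the limit of < 100000 nM in this assay, at which 1 of the 3 values shown sits. Compound 4 carries the same dichlorophenyl ring as compound 1, and in this assay compound 1 gives 4270 nM. Compound 4 is expected to land near that value and is estimated at 6000 nM, within 1200 nM to 40000 nM. That would mean an expected step that the limit leaves unreadable from compound 3 to compound 4 toward stronger inhibition.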

Compound 4, concentration for total growth inhibition: 30900 nM
Beside the measured number, compound 4's estimate is 5.2-fold (0.71 log units) below it; the range from low to high includes it.
By their numbers in this assay, from the lowest: compound 1; then compounds 2 and 4 (each within the scatter of the next).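

No size can be read for the step between compound 3 and compound 4, because compound 3 has only a limit: the limit of < 100000 nM in this assay, at which 1 of the 4 values shown sits. As far as these compounds go, how far (3,4-dichlorophenyl)sulfanyl in place of (4-fluorobenzyl)amino shifts the result in this assay stays open.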